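Notes on the piperidine for methylpiperazine exchange

A few compounds are considered here, and "the series" means these few. Any claim that something is new, unique, unknown or untested is made for them only; others in the source may bear on it.

Compound 1 `CN1CCN(c2ccc(Nc3ncc4c(n3)N(C3CCCC3)CC(=O)N4)nc2)CC1` and compound 2 `O=C1CN(C2CCCC2)c2nc(Nc3ccc(N4CCCCC4)cn3)ncc2N1` share one core; compound 3 `CN1CCN(c2ccc(Nc3ncc4c(n3)N(C3CCCC3)CC(=O)N4C)cc2)CC1` sits on another, and the difference between the two cores is not broken down here. In a functional assay on HeLa cells (Homo sapiens) for inhibition, read by MTT assay, with a stated time of 48 h (a higher number here means a weaker inhibitor, a lower number a stronger inhibitor), compound 1 gives > 30000 nM, which is a limit of the assay rather than a number. Compound 2 likewise gives > 30000 nM in this assay, again a limit. The change between them, (piperidin-1-yl in place of 4-methylpiperazin-1-yl on an aromatic carbon), gives a step that the two limits leave unreadable from compound 1 to compound 2, and the limit of > 30000 nM in this assay, at which 2 of the 3 values shown sit, leaves its size unreadable. Within the data shown here, compound 3 gives 6750 nM in this assay, the only plain number in the set.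

Compound 4 `CN1C(=O)CN(C2CCCC2)c2nc(Nc3ccc(N4CCCCC4)cc3)ncc21` is not yet measured. It carries the same kind of change as compound 2, (piperidin-1-yl in place of 4-methylpiperazin-1-yl on an aromatic carbon), but here on a six-membered aromatic ring of carbon only rather than on a ring with one nitrogen, two atoms from the ring nitrogen. With the earlier step unreadable, no size can be carried over, so the step expected in this assay is a 1.8-fold higher number from compound 3 to compound 4 (0.25 log units; within the scatter), a modest allowance for weakening that rests only on the open uncertainty of that earlier step. Compound 4 is estimated at 12000 nM, expected to fall between 4000 nM and 30000 nM.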

Compound 4, half-maximal inhibitory concentration: 16900 nM
The estimate for compound 4 lay 1.4-fold (0.15 log units) below the measured number, and the stated range covers the measured number.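

In this assay, piperidin-1-yl in place of 4-methylpiperazin-1-yl, on an aromatic carbon of a six-membered aromatic ring of carbon only, gives a 2.5-fold higher number from compound 3 to compound 4 (0.40 log units; beyond the scatter), so on this core the exchange costs a modest amount of inhibition. This is a single readable pair and shows the direction and size of the step on the core of compound 3 only; it does not show that the step carries over to another core, since the two cores also differ in the aromatic ring that bears the group. The matching step from compound 1 to compound 2 cannot be read, because both values there are limits and not numbers: the limit of > 30000 nM in this assay, at which 2 of the 4 values shown sit.

Still open, on these data alone, is whether any compound on the core of compound 1 gives a plain number in this assay, which a comparison of the two cores would need. Also open, as far as these compounds go, is how other groups in the same place behave, such as morpholin-4-yl or an open-chain dimethylamino group, or a carboxylic acid on the piperidine ring.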